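The source may report more compounds than this note shows. Statements on the series, on what has been measured and on what is new or still open speak of the compounds shown alone.

Compound 1 `CCOC(=O)/C=C/C1=CC[C@H]2C(C)(C)CCC[C@]2(C)[C@H]1C=O` and compound 2 `CC1(C)CCC[C@]2(C)[C@@H](C=O)C(/C=C/C(=O)OCc3ccccc3)=CC[C@@H]12` share one core and differ only in the group on the ester oxygen. In a functional assay on U-373MG ATCC cells (Homo sapiens) for inhibition, read by MTT assay, with a stated time of 72 h (on this read-out lower numbers stand for stronger inhibition of growth and higher numbers for weaker inhibition of growth), compound 1 gives 37000 nM, and compound 2 gives 39000 nM; the step of a 1.1-fold higher number from compound 1 to compound 2 (0.02 log units; within the scatter) stays within the scatter. On these two numbers compound 1 stands at the lower end, with compound 2 close beside it.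

Compound 3 `CC1(C)CCC[C@]2(C)[C@@H](C=O)C(/C=C/C#N)=CC[C@@H]12` is not yet measured in this assay. Against compound 1 the change is cyano in place of ethoxycarbonyl on a double-bonded chain carbon bound to a double-bonded chain carbon. Going by the values given here, the only step on record, from compound 1 to compound 2, alters the group on the ester oxygen rather than the ester itself and was flat; no measured pair replaces the ethoxycarbonyl group with a cyano group, so the bearing of that step is indirect. The expectation for compound 3 in this assay is therefore a number near that of compound 1, with a step of a 1.1-fold lower number from compound 1 to compound 3 (0.02 log units; within the scatter) expected to fall within the scatter. Compound 3 is estimated at 35000 nM, with a range from 12000 nM to 100000 nM.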

Compound 3, concentration for 50% growth inhibition: 36000 nM
The estimate for compound 3 lay 1.0-fold (0.01 log units) below the measured number; the measured number falls inside the stated range.
By their numbers in this assay, from the lowest: compounds 3, 1 and 2 (each within the scatter of the next).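

In this assay the change gives a 1.0-fold lower number from compound 1 to compound 3 (0.01 log units; within the scatter), so at this place on a double-bonded chain carbon bound to a double-bonded chain carbon, cyano can stand in place of the whole ethoxycarbonyl group with no step beyond the scatter. The step to compound 2 altered only the group on the ester oxygen and left the ester in place, whereas compound 3 carries no ester at all and still stays within the scatter of compound 1 and compound 2. No evidence is at hand on what lies behind this flat result.

On these data alone, whether the number stays flat with a carboxylic acid, a primary amide or an amine at this place remains open. Also open, as far as these compounds go, is whether a change elsewhere on the shared core, such as at the aldehyde, would move the number in this assay at all.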